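The source may report more compounds than this note shows. Statements on the series, on what has been measured and on what is new or still open speak of the compounds shown alone.

Among the compounds with values here, in a functional assay on K562 cells (Homo sapiens) for antiproliferative activity, read by MTT assay (a higher number here means a weaker inhibitor, a lower number a stronger inhibitor), compound 2 (`C=CCOC(=O)N1CCCc2cc(S(=O)(=O)N3CC(c4ccccc4)NC3=O)ccc21`) gives 473 nM and holds the lower of the two numbers so far, while compound 1 (`CCCCOC(=O)N1CCCc2cc(S(=O)(=O)N3CC(c4ccccc4)NC3=O)ccc21`) gives 3680 nM in the same read-out. Going to compound 3 (`O=C(c1ccccc1)N1CCCc2cc(S(=O)(=O)N3CC(c4ccccc4)NC3=O)ccc21`) makes the change phenyl in place of allyloxy on a carbonyl carbon in which phenyl takes the place of allyloxy on a carbonyl carbon. Within the data shown here, the single measured step, a 7.8-fold lower number from compound 1 to compound 2 (0.89 log units; beyond the scatter) and beyond the scatter, altered the group that now leaves, so this part of the molecule can move the number, but no measured compound carries phenyl there. Among the measured compounds shown here, with compound 2 at 473 nM as the lower of only two values, a modest move to a higher number is expected in this assay though the direction is not secure. The expected change is a 2.5-fold higher number from compound 2 to compound 3 (0.40 log units; beyond the scatter) as an estimate only. For compound 3 the estimated value is 1200 nM within a range of 250 nM to 6000 nM on present data.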

Compound 3, half-maximal inhibitory concentration: 1220 nM
Estimate against measurement, compound 3: 1.0-fold (0.01 log units) below, within the range that was stated.
By their numbers in this assay, from the lowest: compound 2; then compound 3; then compound 1.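

In this assay, the place on the carbonyl carbon does not depend on an oxygen-linked chain: phenyl in place of allyloxy gives a modest loss (a 2.6-fold higher number from compound 2 to compound 3 (0.41 log units; beyond the scatter)), whereas phenyl in place of butoxy gives a modest gain (a 3.0-fold lower number from compound 1 to compound 3 (0.48 log units; beyond the scatter)). The effect of phenyl therefore depends on the group it is compared with, and the ring with no hydrogen-bond acceptor places compound 3 inside the span set by compound 1 and compound 2. No measured evidence explains this order.

From the compounds shown here alone, it remains open whether the advantage of allyloxy over butoxy rests on the double bond itself or would extend to other short unsaturated chains, such as propargyloxy. Also open, going by these compounds, is how benzyloxy, a pyridine ring, an amine or a substituted phenyl on the carbonyl carbon would compare with phenyl.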